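Side chain on sulfur: compound 3 to compound 4

This account rests on a few compounds, and the source may have more. Where it says the series, first, only, none or still open, it means among the compounds named here.

Of the compounds shown here, three with a shared core have been measured in a functional assay on KB cells (Homo sapiens) for inhibition; on this read-out higher numbers stand for weaker inhibition and lower numbers for stronger inhibition: compound 1 `C=CCSc1nc2cc(Cl)c(Cl)cc2n1C1O[C@H](CO)[C@@H](O)[C@H]1O` gives 68000 nM, compound 2 `COc1ccc(CSc2nc3cc(Cl)c(Cl)cc3n2C2O[C@H](CO)[C@@H](O)[C@H]2O)cc1` gives 41000 nM, and compound 3 `OC[C@H]1OC(n2c(SCc3cccc(Cl)c3)nc3cc(Cl)c(Cl)cc32)[C@H](O)[C@@H]1O` gives 19000 nM. Compound 3 has the lowest number of the three, and its gaps to both others lie beyond the scatter.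

The next structure is compound 4 `OC[C@H]1OC(n2c(SCc3ccccc3Cl)nc3cc(Cl)c(Cl)cc32)[C@H](O)[C@@H]1O`. The change is 2-chlorophenyl in place of 3-chlorophenyl on a saturated chain carbon bound to a sulfur, with 2-chlorophenyl in place of 3-chlorophenyl on a saturated chain carbon bound to a sulfur.

All three measured steps sit at this same place. The step of a 1.7-fold lower number from compound 1 to compound 2 (0.22 log units; within the scatter) stays within the scatter, while a 3.6-fold lower number from compound 1 to compound 3 (0.55 log units; beyond the scatter) and a 2.2-fold lower number from compound 2 to compound 3 (0.33 log units; beyond the scatter) are modest. Among the measured compounds shown here, no measured compound carries 2-chlorophenyl, so the data give no direction for this change. The closest guide is the step between two substituted phenyl groups, a 2.2-fold lower number from compound 2 to compound 3 (0.33 log units; beyond the scatter), which suggests that any shift in this assay should be modest at most. No step beyond the scatter is expected, and the expected outcome is a 1.2-fold higher number from compound 3 to compound 4 (0.08 log units; within the scatter). For compound 4 the estimated value is 23000 nM, with an expected range of 10000 nM to 52000 nM.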

Compound 4, half-maximal inhibitory concentration: 30000 nM
The estimate for compound 4 lay 1.3-fold (0.12 log units) below the measured number; the measured number falls inside the stated range.
By their numbers in this assay, from the lowest: compounds 3, 4, 2 and 1 (each within the scatter of the next, the first and the last beyond it).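

Working notes on the side chain on sulfur. In this assay, 2-chlorophenyl in place of 3-chlorophenyl on a saturated chain carbon bound to a sulfur gives a 1.6-fold higher number from compound 3 to compound 4 (0.20 log units; within the scatter), so this rearrangement of the same atoms does not separate the two chlorophenyl groups on this read-out. Against the other two side chains, 2-chlorophenyl gives a 1.4-fold lower number from compound 2 to compound 4 (0.14 log units; within the scatter) and a 2.3-fold lower number from compound 1 to compound 4 (0.36 log units; beyond the scatter), so compound 4, like compound 3, stands apart from the vinyl compound, whereas compound 2 does not, and compound 4 lies within the scatter of both compound 2 and compound 3 even though those two are apart from each other. Nothing in hand bears on the reason for these steps.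

The compounds shown leave open whether 4-chlorophenyl at this place would stay with the other two chlorophenyl groups or fall nearer to 4-methoxyphenyl. They also leave open whether a longer chain between the sulfur and the phenyl ring, or an amine or a carboxylic acid on that ring, would move the number further than any step seen so far.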